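Benzimidazole series: MDBK tolerance, compound 3 to compound 4

The source may hold more compounds than are shown below. What is called first, only, known or untested is meant among the compounds shown, and "the series" means these compounds.

Measured compounds:
- compound 1, `O=C(CN1CCCCC1)Nc1ccc(-c2nc3cc(C(F)(F)F)ccc3[nH]2)cc1`: 6000 nM
- compound 2, `CC(=O)Nc1ccc(-c2nc3ccccc3[nH]2)cc1`: > 100000 nM
- compound 3, `O=C(CN1CCCC1)Nc1ccc(-c2nc3cc(C(F)(F)F)ccc3[nH]2)cc1`: 15000 nM

In an ADME assay on MDBK cells (Bos taurus) for cytotoxicity, read by MTT assay, with a stated time of 96 h (a higher number here means that more compound is tolerated, a lower number that less compound is tolerated), compound 3 stands highest of the two numbers shown, with compound 1 the nearest at 6000 nM. The step from compound 1 to compound 3 is a 2.5-fold higher number from compound 1 to compound 3 (0.40 log units; beyond the scatter). Compound 2 gives only a limit, > 100000 nM; it is a limit of the assay and not a number (the limit of > 100000 nM in this assay, at which 1 of the 3 values shown sits).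

Compound 4, `Oc1ccc(-c2nc3cc(C(F)(F)F)ccc3[nH]2)cc1`, differs from compound 3 by hydroxy in place of (((pyrrolidin-1-yl)methyl)carbonyl)amino on an aromatic carbon. No measured step covers this change: the single step shown, from compound 1 to compound 3, touches only the saturated ring on the side chain and was modest. The change to compound 4 is larger, so a step beyond the scatter in this assay is possible, but its direction is not given by the data.

Compound 4 is expected to give about 30000 nM in this assay, within 8000 nM to 100000 nM, which would mean a step of a 2.0-fold higher number from compound 3 to compound 4 (0.30 log units; within the scatter).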

Compound 4, half-maximal cytotoxic concentration: 51000 nM
Compound 4: the middle estimate sits 1.7-fold (0.23 log units) below what was measured, within the range that was stated.
By their numbers in this assay, from the lowest: compound 1; then compound 3; then compound 4. At a limit, above all of these: compound 2.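

On this aromatic carbon, para to a large group, the side chain is not required for the level of tolerance seen so far in this assay, since hydroxy in its place gives a 3.4-fold higher number from compound 3 to compound 4 (0.53 log units; beyond the scatter) and so moves the number upward. The earlier step, a 2.5-fold higher number from compound 1 to compound 3 (0.40 log units; beyond the scatter) for the change of saturated ring, left the amide-linked chain in place and could not show what removing all of it does. No information at hand gives a cause for the new step.

The shown compounds do not separate the loss of the side chain from the entry of hydroxy. A methoxy group, an amine or a carboxylic acid on the same carbon would test whether hydroxy itself matters here.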